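Replacing the difluoropiperidine amide with a methoxypyrrolidine

This account rests on a few compounds, and the source may have more. Where it says the series, first, only, none or still open, it means among the compounds named here.

compound 1, `CCN(CC)S(=O)(=O)c1ccc(S(=O)(=O)N2CCC[C@@H](C(=O)N3CCC(F)(F)CC3)C2)cc1`: 19 nM
compound 2, `CCN(CC)S(=O)(=O)c1ccc(S(=O)(=O)N2CCC[C@@H](C(=O)N3CCC(O)CC3)C2)cc1`: 230 nM
compound 3, `CCN(CC)S(=O)(=O)c1ccc(S(=O)(=O)N2CCC[C@@H](C(=O)N3CCC(C(F)F)CC3)C2)cc1`: 140 nM

In a functional assay on MIA PaCa-2 cells (Homo sapiens) for inhibition, read by MTT assay, with a stated time of 3 days (a lower number here means a stronger inhibitor, a higher number a weaker inhibitor), compound 1 gives the lowest of the three numbers; compound 3 and compound 2 sit above it, both beyond the scatter. Compound 4 is `CCN(CC)S(=O)(=O)c1ccc(S(=O)(=O)N2CCC[C@@H](C(=O)N3CC[C@H](OC)C3)C2)cc1`. It differs from compound 1 by 3-methoxypyrrolidin-1-yl in place of 4,4-difluoropiperidin-1-yl on a carbonyl carbon. Among the measured compounds shown here, two measured steps bear on this, since each replaces the same 4,4-difluoropiperidin-1-yl group: a 12-fold higher number from compound 1 to compound 2 (1.08 log units; beyond the scatter) and a 7.4-fold higher number from compound 1 to compound 3 (0.87 log units; beyond the scatter). Both swaps raised the number clearly, and neither kept the potency of compound 1. A rise beyond the scatter is therefore expected for compound 4, of a size comparable to those two, giving an expected step of a 7.9-fold higher number from compound 1 to compound 4 (0.90 log units; beyond the scatter). Compound 4 is estimated at 150 nM, within 50 nM to 500 nM.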

Compound 4, half-maximal inhibitory concentration: 460 nM
Compound 4: the middle estimate sits 3.1-fold (0.49 log units) below what was measured, and the stated range covers the measured number.
By their numbers in this assay, from the lowest: compound 1; then compounds 3, 2 and 4 (each within the scatter of the next, the first and the last beyond it).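

In this assay, a five-membered ring carrying a methoxy group also fails to hold the potency of the 4,4-difluoropiperidin-1-yl amide (a 24-fold higher number from compound 1 to compound 4 (1.38 log units; beyond the scatter)). The 3-methoxypyrrolidin-1-yl amide also gives a clearly higher number than the 4-(difluoromethyl)piperidin-1-yl amide (a 3.3-fold higher number from compound 3 to compound 4 (0.52 log units; beyond the scatter)), but cannot be separated from the 4-hydroxypiperidin-1-yl amide (a 2.0-fold higher number from compound 2 to compound 4 (0.30 log units; within the scatter)). Nothing given here accounts for these steps.

Going by these compounds, whether the ring size or the methoxy group matters more stays open. A 4-methoxypiperidin-1-yl amide or a 3,3-difluoropyrrolidin-1-yl amide would separate the two.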